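The compounds below may be only part of what the source reports. "The series", "measured", "known", "first", "only" and "open" are said of these compounds alone.

Compound 1 `Nc1ncnc2c1c(-c1ccco1)cn2[C@H]1C[C@H](O)[C@@H](CO)O1` and compound 2 `Nc1ncnc2c1c(-c1ccoc1)cn2[C@H]1C[C@H](O)[C@@H](CO)O1` share one core and differ only in the aromatic group carried on it. In a toxicity assay on Huh-7 cells (Homo sapiens) for cytotoxicity, with a stated time of 3 days (on this read-out lower numbers stand for higher toxicity in this test and higher numbers for lower toxicity in this test), compound 1 gives only a limit, > 44000 nM. In this assay compound 2 also gives only a limit, > 44000 nM. The step that the two limits leave unreadable from compound 1 to compound 2 cannot be read, since both values sit at the limit of > 44000 nM in this assay, at which 2 of the 2 values shown sit. Compound 3 `Nc1ncnc2c1c(-c1ccsc1)cn2[C@H]1C[C@H](O)[C@@H](CO)O1` is the next member; the change from compound 2 is thiophen-3-yl in place of furan-3-yl on an aromatic carbon. No readable step bears on this change, so nothing in the data argues for a shift beyond the scatter in this assay in either direction. Compound 3 is therefore expected to stay near the limit, with an estimated step of a number no higher from compound 2 to compound 3 (the limit leaves the size open). The estimate for compound 3 in this assay is 44000 nM, with a range from 20000 nM to 100000 nM.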

Compound 3, half-maximal cytotoxic concentration: > 44000 nM
Compound 3 was reported as a limit; the forecaster's own chance of this, stated with the estimate: 85%; the middle value lies on the limit itself.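

In this assay compound 3 also gives only a limit, > 44000 nM. Going by these compounds alone, no step among compound 1, compound 2 and compound 3 can be read: the limit of > 44000 nM in this assay, at which 3 of the 3 values shown sit. These compounds leave open whether furan-2-yl, furan-3-yl and thiophen-3-yl differ at all in cytotoxicity.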